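Hydroxycarbamoyl in place of methoxycarbonyl on the benzyl ester

The compounds below may be only part of what the source reports. "The series", "measured", "known", "first", "only" and "open" are said of these compounds alone.

The series is followed in an assay on HEK293 cells for inhibition of Ataxin-2 (Mus musculus), read by fluorescence and Amplex Red; a lower number here means a stronger inhibitor, a higher number a weaker inhibitor. Compound 1 `COC(=O)c1ccc(COc2ccc(CNC(=O)[C@@H]3CCC(=O)N3Cc3ccccc3)cc2)cc1` gives only a limit there, > 5000 nM, so its place among the measured compounds is unresolved; it shares the limit of > 5000 nM in this assay, at which 2 of the 3 values shown sit, with compound 3. Compound 3 `O=C1CC[C@@H](C(=O)NCc2ccc(OCc3ccc(C(=O)O)cc3)cc2)N1` also reaches only a limit in this assay, > 5000 nM. Among the measured compounds shown here, compound 2 `CC1(C)OB(c2ccc(COc3ccc(CNC(=O)[C@H]4CCC(=O)N4Cc4ccccc4)cc3)cc2)OC1(C)C` is the one member with a number in this assay, 180 nM. For the measured compounds named here, no pair of measured compounds differs in a single place, so no measured step is available, and the position of compound 1 relative to compound 2 can be read only as a limit against a number.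

Compound 4 `O=C(NO)c1ccc(COc2ccc(CNC(=O)[C@@H]3CCC(=O)N3Cc3ccccc3)cc2)cc1` differs from compound 1 by hydroxyamino in place of methoxy on a carbonyl carbon, in words hydroxyamino in place of methoxy on a carbonyl carbon. Whether this change moves the read-out cannot be taken from any measured step here. The expectation is nonetheless a gain in this assay, an at least 12-fold lower number from compound 1 to compound 4 (1.09 log units; beyond the scatter), a step beyond the usual scatter, because compound 1 sits at the limit of > 5000 nM in this assay, at which 2 of the 3 values shown sit, and only compound 2 among the measured compounds returns a number there. Compound 4 is accordingly expected to come in near 400 nM, within a range from 80 nM to 3000 nM, with a real chance that the assay again reports only a limit.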

Compound 4, half-maximal inhibitory concentration: 700 nM
Compound 4: the middle estimate sits 1.8-fold (0.24 log units) below what was measured; the range from low to high includes it.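

In this assay, among the compounds shown here, hydroxyamino in place of methoxy on a carbonyl carbon gives an at least 7.1-fold lower number from compound 1 to compound 4 (0.85 log units; beyond the scatter), the first step that can be read across a single change. The place therefore tolerates change and responds to it: the 4-(methoxycarbonyl)benzyl group gives no number, whereas the 4-(hydroxycarbamoyl)benzyl group does, with 2 hydrogen-bond donors entering and 0 leaving and the heavy-atom count unchanged. Compound 1 gives only a limit, so the step fixes a minimum size and not a true size, because the starting point stands at: the limit of > 5000 nM in this assay, at which 2 of the 4 values shown sit.

Still open, on these data alone, is whether the gain depends on the oxygen of hydroxyamino or on the nitrogen alone, a question that an amino or methylamino group on the same carbonyl carbon would address. A carboxylic acid at this place on the core of compound 1, or a longer chain between the carbonyl and the hydroxyamino group, would show how narrowly the read-out depends on the hydroxycarbamoyl group itself.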